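Moving the fluorine on the anilino ring of a shared core

A few compounds are considered here, and "the series" means these few. Any claim that something is new, unique, unknown or untested is made for them only; others in the source may bear on it.

Compound 1, `Cc1cc(-c2cnn3c(NCC4CCOCC4)nc(Oc4cccc(F)c4F)nc23)ccc1C(=O)NC1CC1`: 12 nM
Compound 2, `Cc1cc(-c2cnn3c(NCC4CCOCC4)nc(Nc4cccc(F)c4)nc23)ccc1C(=O)NC1CC1`: 16 nM

In a functional assay on MDA-MB-231 cells (Homo sapiens) for antiproliferative activity (a lower number here means a stronger inhibitor of growth, a higher number a weaker inhibitor of growth), compound 2 gives the higher of the two numbers, yet the step of a 1.3-fold higher number from compound 1 to compound 2 (0.12 log units; within the scatter) means the two values cannot be told apart. Compound 3, `Cc1cc(-c2cnn3c(NCC4CCOCC4)nc(Nc4ccccc4F)nc23)ccc1C(=O)NC1CC1`, differs from compound 2 by 2-fluorophenyl in place of 3-fluorophenyl on a nitrogen on an aromatic ring. Among the compounds with values here, no measured step tests this shift of fluorine on its own; the only step available, from compound 1 to compound 2, changes the link and the fluorine pattern together and lies within the scatter. Compound 3 is therefore expected to show no step beyond the scatter, a 1.3-fold higher number from compound 2 to compound 3 (0.10 log units; within the scatter). Compound 3 is estimated at 20 nM, within 8 nM to 60 nM.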

Compound 3, concentration for 50% growth inhibition: 47 nM
For compound 3 the middle estimate is 2.4-fold (0.37 log units) below the measured one; low and high end bracket the measured number.
By their numbers in this assay, from the lowest: compounds 1 and 2 (each within the scatter of the next); then compound 3.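

In this assay, where the single fluorine sits on the ring matters: 2-fluorophenyl in place of 3-fluorophenyl on the nitrogen, with the same atoms joined differently, gives a step beyond the scatter (a 2.9-fold higher number from compound 2 to compound 3 (0.47 log units; beyond the scatter)). Replacing 2,3-difluorophenoxy with (2-fluorophenyl)amino on the aromatic carbon also gives such a step (a 3.9-fold higher number from compound 1 to compound 3 (0.59 log units; beyond the scatter)), whereas (3-fluorophenyl)amino there gave none. No evidence at hand accounts for this difference. The compounds shown leave open how a plain phenyl ring or a chlorophenyl group on that nitrogen would compare.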